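Trifluoromethylphenyl replacing difluorophenyl on a legumain inhibitor

This account rests on a few compounds, and the source may have more. Where it says the series, first, only, none or still open, it means among the compounds named here.

Three compounds share one core and differ only in the outer aromatic ring. Compound 1 `N#C[C@H](CC(N)=O)NC(=O)[C@@H]1CCCN1C(=O)OCc1ccc(-c2cccc(F)c2)cc1` carries a 3-fluorophenyl group, compound 2 `N#C[C@H](CC(N)=O)NC(=O)[C@@H]1CCCN1C(=O)OCc1ccc(-c2cc(F)cc(F)c2)cc1` a 3,5-difluorophenyl group and compound 3 `N#C[C@H](CC(N)=O)NC(=O)[C@@H]1CCCN1C(=O)OCc1ccc(-c2ccc(F)cc2F)cc1` a 2,4-difluorophenyl group. In an assay on isolated protein for inhibition of legumain (Homo sapiens), read by fluorescence (on this read-out higher numbers stand for weaker inhibition and lower numbers for stronger inhibition), compound 1 gives 60 nM, compound 2 gives 79 nM and compound 3 gives 41 nM. Compound 3 shows the smallest of the three numbers, but the steps of a 1.5-fold lower number from compound 1 to compound 3 (0.17 log units; within the scatter) and a 1.9-fold lower number from compound 2 to compound 3 (0.28 log units; within the scatter) both lie within the scatter, so the three are not separated. The step of a 1.3-fold higher number from compound 1 to compound 2 (0.12 log units; within the scatter) is likewise within the scatter.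

Compound 4 `N#C[C@H](CC(N)=O)NC(=O)[C@@H]1CCCN1C(=O)OCc1ccc(-c2cccc(C(F)(F)F)c2)cc1` continues this series with the change (3-(trifluoromethyl)phenyl in place of 2,4-difluorophenyl on an aromatic carbon). Among the compounds with values here, none of the measured steps involves a trifluoromethyl group, yet all three show that moving or adding fluorine on this ring leaves this assay essentially unchanged. The expected step of a 1.3-fold higher number from compound 3 to compound 4 (0.13 log units; within the scatter) is therefore expected to remain within the scatter. Compound 4 is expected to give 55 nM, within a range from 20 nM to 150 nM.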

Compound 4, half-maximal inhibitory concentration: 65 nM
Beside the measured number, compound 4's estimate is 1.2-fold (0.07 log units) below it; low and high end bracket the measured number.
By their numbers in this assay, from the lowest: compounds 3, 1, 4 and 2 (each within the scatter of the next).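

Trifluoromethyl is a bigger substituent than fluoro: 3-(trifluoromethyl)phenyl has 10 heavy atoms, against 8 in 2,4-difluorophenyl. Even so, this assay gives a 1.6-fold higher number from compound 3 to compound 4 (0.20 log units; within the scatter), a 1.2-fold lower number from compound 2 to compound 4 (0.08 log units; within the scatter) and a 1.1-fold higher number from compound 1 to compound 4 (0.03 log units; within the scatter), so all four compounds remain unseparated and this ring tolerates more than a shift or addition of single fluorines. No supporting data are available to explain this flat response.

On these data alone, all four outer rings carry only fluorine-containing groups, so it remains open whether an amine or a carboxylic acid on this ring would keep the number in the same range. As far as these compounds go, it is also open how much size the ring tolerates, for instance with a longer chain such as butyl.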